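Swapping the Acyl Group on the Ester of Compound 2

The source may hold more compounds than are shown below. What is called first, only, known or untested is meant among the compounds shown, and "the series" means these compounds.

Measured so far:
compound 1 `Cc1nc2c(OCc3ccccc3)cccn2c1CS(C)(=O)=O`: 0%
compound 2 `CC(=O)OCc1c(C)nc2c(OCc3ccccc3)cccn12`: 87%

In a functional assay on the whole organism (stomach) for inhibition, with Canis familiaris (Canis lupus familiaris) as the target, at a dose of 5 mg/kg by the intravenous route (a higher number here means a stronger effect of the compound at the dose given, a lower number a weaker effect), compound 1 gives 0%, and compound 2 gives 87%, the higher of the two numbers. Compound 3 `Cc1nc2c(OCc3ccccc3)cccn2c1COC(=O)c1cccnc1` differs from compound 2 by pyridin-3-yl in place of methyl on a carbonyl carbon, acetoxy becoming ((pyridin-3-yl)carbonyl)oxy. Among the measured compounds shown here, the only measured step, a number 87 percentage points higher from compound 1 to compound 2 (beyond the scatter), replaces the whole group on a saturated chain carbon bound to an aromatic carbon, so it bears only loosely here; it shows that acetoxy at that place gives strong inhibition. With only the carbonyl carbon's substituent changing, a step of a number 9 percentage points lower from compound 2 to compound 3 (within the scatter) is expected, within the scatter. Compound 3 is estimated at 78%, between 45% and 97%.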

Compound 3, a percentage reported as inhibition, in the whole organism at one dose (the size of the read-out at that dose, not a potency): 88%
The estimate for compound 3 lay 10 percentage points below the measured number; measured number inside the range.
By their numbers in this assay, from the lowest: compound 1; then compounds 2 and 3 (each within the scatter of the next).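

In this assay, the carbonyl carbon of the ester can carry a ring as well as a small methyl: pyridin-3-yl in place of methyl gives a number 1 percentage points higher from compound 2 to compound 3 (within the scatter) and leaves the two esters indistinguishable at this dose. The second ester also separates from the sulfone, with a number 88 percentage points higher from compound 1 to compound 3 (beyond the scatter) showing that strong inhibition is not confined to acetoxy. No supporting data bear on this result. Open, from the compounds shown here alone, is whether a longer chain on that carbonyl carbon, or an amine in place of the ester on the chain carbon, would give similar inhibition. A single dose also leaves any difference in potency between compound 2 and compound 3 unresolved.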